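Mirror-image pair in the difluorinated oxolane quaternary ammonium series

The compounds below may be only part of what the source reports. "The series", "measured", "known", "first", "only" and "open" are said of these compounds alone.

Within the data shown here, compound 2 `C[C@@H]1O[C@@H](C[N+](C)(C)C)CC1(F)F` gives 4.16 in a functional assay with muscarinic acetylcholine receptor M3 (Cavia porcellus) as the target (on this read-out lower numbers stand for lower potency and higher numbers for higher potency (the scale is a negative logarithm)), and stands highest of the two numbers measured so far. Among the measured compounds shown here, compound 1 `C[C@H]1O[C@@H](C[N+](C)(C)C)CC1(F)F` gives 3.82 in this assay, and the step of a number 0.34 log units higher from compound 1 to compound 2 (beyond the scatter) is the only measured step in the set; it rests on (the fact that compounds 1 and 2 differ only in the configuration as drawn). Compound 3 `C[C@H]1O[C@H](C[N+](C)(C)C)CC1(F)F` is not yet measured. Its difference from compound 2 is the two compounds have the same atoms and bonds and differ only in configuration as drawn: 2 of 2 stereo elements differ (all stereocentres are inverted: mirror images); a stereocentre at a saturated ring carbon is drawn S in compound 2 and R in compound 3; a stereocentre at a saturated ring carbon is drawn R in compound 2 and S in compound 3. For the measured compounds named here, no measured step in this set compares mirror images, so the single diastereomeric step, which was modest, is the only guide; it suggests that configurational changes move this read-out by modest amounts here, but gives no direction for a full inversion. For compound 3 a modest drop in this assay is expected, with the range kept wide, as 3.9 between 3.3 and 4.5. The step of a number 0.26 log units lower from compound 2 to compound 3 (within the scatter) is the expected change.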

Compound 3, negative logarithm of the half-maximal effective concentration: 3.95
For compound 3 the middle estimate is 0.05 log units below the measured one; low and high end bracket the measured number.
By their numbers in this assay, from the lowest: compounds 1, 3 and 2 (each within the scatter of the next, the first and the last beyond it).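

In this assay, full inversion to the mirror image gives a number 0.21 log units lower from compound 2 to compound 3 (within the scatter), so both stereocentres can be inverted together without a step beyond the scatter. Among these compounds, the other new step, a number 0.13 log units higher from compound 1 to compound 3 (within the scatter), inverts a different stereocentre from the one changed in a number 0.34 log units higher from compound 1 to compound 2 (beyond the scatter), and only the latter lies beyond the scatter, so the two single inversions from compound 1 do not read alike. Compound 3 cannot be separated from either compound 1 or compound 2, and the mirror-image comparison rests on one structural fact: the fact that compounds 2 and 3 differ only in the configuration as drawn

Going by these compounds, the reading of the remaining combination of the two stereocentres stays open. So does whether this small stereochemical spread would persist with an ethyl group in place of the methyl or a tertiary amine in place of the trimethylammonium.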